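Coumarin-3-carboxamide series: hydrazide in place of isopropylamide

The compounds below may be only part of what the source reports. "The series", "measured", "known", "first", "only" and "open" are said of these compounds alone.

Measured compounds:
- compound 1 `O=C(NCCNC(=O)c1cc2ccc(OCc3cccc(Br)c3)cc2oc1=O)c1cc2ccc(OCc3cccc(Br)c3)cc2oc1=O`: 5520 nM
- compound 2 `CCN(CC)c1ccc2cc(C(=O)NC(C)C)c(=O)oc2c1`: 73000 nM
- compound 3 `O=C(NO)c1cc2ccc(OCc3ccccc3)cc2oc1=O`: 31800 nM

In a functional assay on HeLa cells (Homo sapiens) for cytotoxicity, read by MTT assay, with a stated time of 72 h (on this read-out higher numbers stand for weaker inhibition and lower numbers for stronger inhibition), compound 2 gives the highest number of the three, so it is the weakest inhibitor among them, with compound 3 nearest and compound 1 furthest from it. Within the data shown here, no single-change pairs exist among the measured compounds, so nothing about the amide substituent can be read from them directly.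

Compound 4 `CCN(CC)c1ccc2cc(C(=O)NN)c(=O)oc2c1` differs from compound 2 by one change: amino in place of isopropyl on an amide-type nitrogen. Among the measured compounds shown here, with no comparable measured pair, the size of the step is unknown; a step of no more than the scatter, in either direction, is expected a 1.2-fold lower number from compound 2 to compound 4 (0.09 log units; within the scatter). Compound 4 is therefore estimated at 60000 nM, within 20000 nM to 180000 nM.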

Compound 4, half-maximal inhibitory concentration: 5480 nM
Estimate against measurement, compound 4: 11-fold (1.04 log units) above; the measured number lies below the stated range.
By their numbers in this assay, from the lowest: compounds 4 and 1 (each within the scatter of the next); then compound 3; then compound 2.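

The substituent on the amide-type nitrogen is a sensitive point in this assay: amino in place of isopropyl gives a 13-fold lower number from compound 2 to compound 4 (1.12 log units; beyond the scatter). One change at this position on the shared core is therefore enough to move the number well beyond the scatter. No measured evidence accounts for the step.

From the compounds shown here alone, it remains open whether the step comes from the entering amino group or from the loss of isopropyl; methyl or a longer alkyl chain on the same nitrogen would help separate the two. Going by these compounds, whether the step carries over to the core of compound 1 or compound 3 also remains open.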